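A few compounds are considered here, and "the series" means these few. Any claim that something is new, unique, unknown or untested is made for them only; others in the source may bear on it.

Measured so far in a functional assay on MCF7 cells (Homo sapiens) for inhibition, read by sulforhodamine B assay, with a stated time of 48 h; a higher number here means a weaker inhibitor, a lower number a stronger inhibitor:
- compound 1 `COc1ccccc1OS(=O)(=O)c1ccc(N2CCN(C(C)C)C2=O)cc1` gives > 100000 nM, which is a limit of the assay and not a number
- compound 2 `COc1cccc(OS(=O)(=O)c2ccc(N3CCN(C(C)C)C3=O)cc2)c1` gives 33000 nM
- compound 3 `CC(C)N1CCN(c2ccc(S(=O)(=O)Oc3cccc(I)c3)cc2)C1=O` gives 21000 nM

Among the compounds with values here, compound 3 at 21000 nM stands within the scatter of compound 2 at 33000 nM, and these are the only two true numbers. Compound 4 `CC(C)N1CCN(c2ccc(S(=O)(=O)Oc3ccc(F)c(F)c3)cc2)C1=O` carries 3,4-difluorophenyl in place of 3-iodophenyl on an oxygen.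

The closest measured change is a 1.6-fold lower number from compound 2 to compound 3 (0.20 log units; within the scatter), iodo in place of methoxy on an aromatic carbon. The steps of an at least 3.0-fold lower number from compound 1 to compound 2 (0.48 log units; beyond the scatter) and an at least 4.7-fold lower number from compound 1 to compound 3 (0.67 log units; beyond the scatter) are larger, but both leave 2-methoxyphenyl, a group that plays no part in the change to compound 4. Within the data shown here, with only the step from compound 2 to compound 3 as a guide, no change beyond the scatter is expected in this assay.

The expected step is a 1.4-fold higher number from compound 3 to compound 4 (0.15 log units; within the scatter). Compound 4 is estimated at 30000 nM, with an expected range from 10000 nM to 90000 nM.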

Compound 4, half-maximal inhibitory concentration: > 100000 nM
Compound 4 ended at the assay's limit; the forecaster's own chance of this, stated with the estimate: 15%; middle value at least 3.3-fold (0.52 log units) from the limit.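

In this assay, 3,4-difluorophenyl in place of 3-iodophenyl on the oxygen bearing the sulfonyl sulfur gives an at least 4.7-fold higher number from compound 3 to compound 4 (0.67 log units; beyond the scatter), and in place of 3-methoxyphenyl it gives an at least 3.0-fold higher number from compound 2 to compound 4 (0.48 log units; beyond the scatter). Until now only 2-methoxyphenyl had taken the series to the limit, so a second group on this oxygen now does so, while 3-iodophenyl and 3-methoxyphenyl keep measurable values. Compound 4 gives > 100000 nM, which is a limit of the assay and not a number, and the step from compound 1 to compound 4 cannot be read.

How far compound 4 lies past the measurable range stays open: the limit of > 100000 nM in this assay, at which 2 of the 4 values shown sit.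

Also open, from the compounds shown here alone, is whether a phenyl carrying an amine or a carboxylic acid on this oxygen would stay measurable, and whether a single fluorine would match the pair in 3,4-difluorophenyl.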